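Difluorophenyl urea on the lactam core of compound 3

The compounds below may be only part of what the source reports. "The series", "measured", "known", "first", "only" and "open" are said of these compounds alone.

Compound 3 `CC[C@H](C)[C@H](NC(=O)N1CCC2(CC1)C(=O)N(C)C2c1ccc(Cl)cc1)C(=O)OC` gives 800 nM in an assay on HEK293 cells for inhibition of Voltage-dependent T-type calcium channel subunit alpha-1H (Homo sapiens), read by patch clamp, using a membrane potential dye (on this read-out lower numbers stand for stronger inhibition and higher numbers for weaker inhibition), the highest number of the three measured; compound 1 `CC[C@H](C)[C@H](NC(=O)N1CCC2(CC1)CN(C)C2c1ccc(Cl)cc1)C(=O)OC` gives 410 nM and compound 2 `CN1CC2(CCN(C(=O)Nc3cc(F)cc(F)c3)CC2)C1c1ccc(Cl)cc1` gives 214 nM. Compound 4 `CN1C(=O)C2(CCN(C(=O)Nc3cc(F)cc(F)c3)CC2)C1c1ccc(Cl)cc1` is not yet measured. Its difference from compound 3 is 3,5-difluorophenyl in place of 1-(methoxycarbonyl)-2-methylbutyl on an amide-type nitrogen. Within the data shown here, the same change on the core of compound 1 is the one measured step that bears on it: a 1.9-fold lower number from compound 1 to compound 2 (0.28 log units; within the scatter). Compound 4 is therefore expected to give a step of about a 1.9-fold lower number from compound 3 to compound 4 (0.28 log units; within the scatter), a lower number of similar size, not clearly beyond the scatter. The estimate for compound 4 in this assay is 420 nM, with a range from 180 nM to 950 nM.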

Compound 4, half-maximal inhibitory concentration: 920 nM
Beside the measured number, compound 4's estimate is 2.2-fold (0.34 log units) below it; low and high end bracket the measured number.
By their numbers in this assay, from the lowest: compounds 2, 1, 3 and 4 (each within the scatter of the next, the first and the last beyond it).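

In this assay, 3,5-difluorophenyl in place of 1-(methoxycarbonyl)-2-methylbutyl on the amide-type nitrogen gives a 1.2-fold higher number from compound 3 to compound 4 (0.06 log units; within the scatter), so the two groups cannot be told apart on the core of compound 3 either. With a second core now read, the change shows no dependence on the core at this position: the same change on two cores in this assay, a 1.9-fold lower number (0.28 log units; within the scatter) from compound 1 to compound 2 and a 1.2-fold higher number (0.06 log units; within the scatter) from compound 3 to compound 4, 2.2-fold (0.34 log units) apart, within the scatter of two such steps.

Neither step shows that this position responds to any change of group at all. From the compounds shown here alone, whether a carboxylic acid in place of the methoxycarbonyl of compound 3, or a simple cyclohexyl in place of 3,5-difluorophenyl, moves the number beyond the scatter stays open.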